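Diethylamino to butyl: a substituent swap

A few compounds are considered here, and "the series" means these few. Any claim that something is new, unique, unknown or untested is made for them only; others in the source may bear on it.

Going by the values given here, compound 1 `CCN(CC)c1ccc(N2C(=O)NC3(CSC4=C3C(=O)c3ncccc3C4=O)C2=O)cc1` holds the lowest of the two numbers so far: in a functional assay on CCRF-CEM cells (Homo sapiens) for antiproliferative activity, read by MTT assay, with a stated time of 96 h (on this read-out higher numbers stand for weaker inhibition and lower numbers for stronger inhibition), compound 1 gives 20 nM. Compound 2 `Cc1ccc(N2NC(=O)NC3(CSC4=C3C(=O)c3ncccc3C4=O)C2=O)cc1` sits higher, with compound 2 at 70 nM in this assay, a gap beyond the usual scatter. Compound 3 `CCCCc1ccc(N2C(=O)NC3(CSC4=C3C(=O)c3ncccc3C4=O)C2=O)cc1` differs from compound 1 by butyl in place of diethylamino on an aromatic carbon. Among the compounds with values here, no measured pair isolates this change, so the expected step is uncertain; a modest loss in this assay, near the edge of the scatter, is expected, namely a 2.0-fold higher number from compound 1 to compound 3 (0.30 log units; within the scatter). Compound 3 is therefore estimated at 40 nM in this assay, with a range from 15 nM to 120 nM.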

Compound 3, half-maximal inhibitory concentration: 150 nM
For compound 3 the middle estimate is 3.8-fold (0.57 log units) below the measured one, outside the stated range (above it).
By their numbers in this assay, from the lowest: compound 1; then compound 2; then compound 3.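

In this assay, going by these compounds alone, the aromatic carbon para to a large group proves sensitive to substitution: butyl in place of diethylamino gives a 7.5-fold higher number from compound 1 to compound 3 (0.88 log units; beyond the scatter), the first step that isolates one change. The swap removes the nitrogen and its hydrogen-bond acceptor, but no available evidence connects either difference to the loss.

Open, on these data alone, is whether another amine, such as dimethylamino or morpholine, would stay close to compound 1. Also open, as far as these compounds go, is whether methoxy or a longer chain would stay closer to compound 3.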